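Amino in Place of Methyl on a Urea Side Chain

A few compounds are considered here, and "the series" means these few. Any claim that something is new, unique, unknown or untested is made for them only; others in the source may bear on it.

Three ureas that share the same fluorinated, trifluoromethyl-bearing aryl group have been measured in an ADME assay on microsomes from liver (Homo sapiens) for metabolic stability, using NADPH, with a stated time of 60 min; a higher number here means faster removal of the compound, a lower number slower removal. Compound 1 `CC(=O)c1ccc(NC(=O)Nc2ccc(F)c(C(F)(F)F)c2)cc1` carries an acetyl group on its second ring and gives 16 uL/min. Compound 3 `O=C(Nc1ccc(F)c(C(F)(F)F)c1)Nc1ccc(F)c(C(F)(F)F)c1`, built from two copies of the fluorinated ring, gives 10 uL/min, a value that lies within the usual scatter of compound 1, so the two cannot be told apart. Compound 2 `O=C(Nc1ccc(F)c(C(F)(F)F)c1)Nc1cnccn1` gives 210 uL/min, which lies far beyond the scatter above compound 1. Compound 1 therefore stands second highest of the three numbers, close to compound 3 and well below compound 2.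

Compound 4 `NC(=O)c1ccc(NC(=O)Nc2ccc(F)c(C(F)(F)F)c2)cc1` differs from compound 1 in one place: amino in place of methyl on a carbonyl carbon. Going by the values given here, no measured pair among the three shows this kind of change, so the expectation rests on the size of the change alone. Compound 1, with 16 uL/min, already sits near the low end of what the three compounds show, and a swap of one heavy atom is expected to move the number only a little. The step of a 1.3-fold lower number from compound 1 to compound 4 (0.12 log units; within the scatter) is expected to stay within the scatter, leaning toward a slightly lower number. Compound 4 is expected to give about 12 uL/min in this assay, with a likely range from 5 uL/min to 30 uL/min.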

Compound 4, intrinsic clearance in a liver preparation (reported as CLH), per the amount of preparation that the assay uses in the Homo sapiens assay: 28 uL/min
Estimate against measurement, compound 4: 2.3-fold (0.37 log units) below; the range from low to high includes it.
By their numbers in the Homo sapiens assay, from the lowest: compounds 3, 1 and 4 (each within the scatter of the next, the first and the last beyond it); then compound 2.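

Going by these compounds alone, replacing the acetyl group of compound 1 with the carbamoyl group of compound 4 gives the first step in this set that changes a single place, and in the Homo sapiens assay it reads a 1.8-fold higher number from compound 1 to compound 4 (0.24 log units; within the scatter), so this change on a carbonyl carbon cannot be told apart from no change in that read-out. In a physicochemical assay for solubility, read by nephelometry, measured as kinetic solubility, at pH 2 (on this read-out higher numbers stand for higher solubility and lower numbers for lower solubility), compound 1 gives < 1.6 ug/mL, which is a limit of the assay and not a number. In the physicochemical assay compound 4 gives 6.3 ug/mL, and the step between the pair reads an at least 3.9-fold higher number from compound 1 to compound 4 (0.59 log units; beyond the scatter), so the change does register on this second read-out, although the true size of the step stays unknown: the limit of < 1.6 ug/mL in the physicochemical assay, at which 1 of the 2 values shown sits.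

The compounds shown leave open how other groups on the same carbonyl carbon would behave in both assays, for example a carboxylic acid or a methylamino group in place of the amino group. Within the data shown here, with only one pair differing in this place, they also leave open whether the same swap would give similar steps on a different core.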